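Amine swap on the propoxy chain: compound 2 to compound 3

The compounds below may be only part of what the source reports. "The series", "measured", "known", "first", "only" and "open" are said of these compounds alone.

For the measured compounds named here, compound 2 `CCN(CC)CCCOc1cc2ncnc(Nc3nc4ccc(C(=O)Nc5c(C)cccc5Cl)cc4s3)c2cc1OC` is one of two compounds measured in a functional assay on K562 cells (Homo sapiens) for cytotoxicity, read by WST assay, with a stated time of 72 h; a lower number here means a stronger inhibitor, a higher number a weaker inhibitor; compound 2 gives 9600 nM. Compound 1 `COc1cc2c(Nc3nc4ccc(C(=O)Nc5c(C)cccc5C)cc4s3)ncnc2cc1OCCCN1CCCC1`, which carries both a different amine on the chain and a different anilide, gives in this assay 15700 nM; the two values lie within the scatter of each other, so no order between them can be claimed. Compound 3 `COc1cc2c(Nc3nc4ccc(C(=O)Nc5c(C)cccc5Cl)cc4s3)ncnc2cc1OCCCN1CCCC1` has not yet been measured in this assay. It differs from compound 2 in one place: pyrrolidin-1-yl in place of diethylamino on a saturated chain carbon, three bonds along the chain from an oxygen on an aromatic ring. Going by the values given here, no measured pair isolates that change, so nothing in these data predicts a step beyond the scatter in either direction. The expected step in this assay is accordingly small: a 1.0-fold higher number from compound 2 to compound 3 (0.02 log units; within the scatter). Compound 3 is estimated at 10000 nM in this assay, with a range from 4000 nM to 25000 nM.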

Compound 3, half-maximal inhibitory concentration: 13300 nM
Compound 3: the middle estimate sits 1.3-fold (0.12 log units) below what was measured, and the stated range covers the measured number.
By their numbers in this assay, from the lowest: compounds 2, 3 and 1 (each within the scatter of the next).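

In this assay the change from diethylamino to pyrrolidin-1-yl on the saturated chain carbon can now be read on its own: it amounts to a 1.4-fold higher number from compound 2 to compound 3 (0.14 log units; within the scatter) and does not separate the two amines. The same holds for chloro in place of methyl on an aromatic carbon, read at a 1.2-fold lower number from compound 1 to compound 3 (0.07 log units; within the scatter), so the comparison of compound 1 with compound 2, which mixed two changes, now resolves into two single steps, neither beyond the scatter. The data available offer no explanation for these values.

From the compounds shown here alone, whether morpholine or piperidine in place of these amines would give a step beyond the scatter remains open. So does the effect of a shorter chain, or of a fluoro or methoxy group in place of the chloro.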